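The source may hold more compounds than are shown below. What is called first, only, known or untested is meant among the compounds shown, and "the series" means these compounds.

Measured in an assay on membranes from brain for binding affinity to Lysophosphatidylserine lipase ABHD12 (Mus musculus), read by fluorescence, with a stated time of 20 min; on this read-out higher numbers stand for weaker inhibition and lower numbers for stronger inhibition:
compound 1 `FC(F)(F)c1cnc(N2CCC(NC(=S)Nc3cccnc3)CC2)c(Cl)c1`: 1100 nM
compound 2 `Cc1c(Oc2ccc(OC(F)(F)F)cc2)ccnc1N1CCC(NC(=S)Nc2cccnc2)CC1`: 26 nM
compound 3 `Cc1cnc(N2CCC(NC(=S)Nc3cccnc3)CC2)c(Cl)c1`: 3100 nM

Compound 2 gives the lowest number of the three in this assay; how its core differs from that of compound 3 is not broken down here. Between compound 3 and compound 1 the change is trifluoromethyl in place of methyl on an aromatic carbon, and it gave a 2.8-fold lower number from compound 3 to compound 1 (0.45 log units; beyond the scatter).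

Compound 4 `FC(F)(F)Oc1ccc(Oc2ccnc(N3CCC(NC(=S)Nc4cccnc4)CC3)c2C(F)(F)F)cc1` is not yet measured. It differs from compound 2 by trifluoromethyl in place of methyl on an aromatic carbon, the same kind of change as from compound 3 to compound 1, though not the same: in compound 4 the group sits ortho to two large groups, while in compound 1 it sits meta to a chloro group and para to a large group. A step of similar direction, a 1.7-fold lower number from compound 2 to compound 4 (0.24 log units; within the scatter), is expected in this assay, resting on a 2.8-fold lower number from compound 3 to compound 1 (0.45 log units; beyond the scatter). Compound 4 is thus estimated at 15 nM, between 5 nM and 60 nM.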

Compound 4, half-maximal inhibitory concentration: 2800 nM
For compound 4 the middle estimate is 190-fold (2.27 log units) below the measured one; the whole stated range lies below it.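

In this assay, trifluoromethyl in place of methyl on an aromatic carbon gives a 110-fold higher number from compound 2 to compound 4 (2.03 log units; beyond the scatter), so the earlier step does not carry over to this core. The two steps differ in direction as well as in size: the same change on two cores in this assay, a 2.8-fold lower number (0.45 log units; beyond the scatter) from compound 3 to compound 1 and a 110-fold higher number (2.03 log units; beyond the scatter) from compound 2 to compound 4, 300-fold (2.48 log units) apart, beyond the scatter of two such steps

The outcome of this change therefore depends on its context, but with one pair on each core the data do not separate the influence of the wider core from that of the place, ortho to two large groups in compound 4, and they give no cause.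

Open, from the compounds shown here alone, is how this assay responds on the core of compound 2 to other groups at this place, such as ethyl or a nitrile. Also open, going by these compounds, is whether the same change at another place on that core would follow compound 4 or compound 1.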